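A few compounds are considered here, and "the series" means these few. Any claim that something is new, unique, unknown or untested is made for them only; others in the source may bear on it.

Of the compounds shown here, two have been measured in a functional assay on MIA PaCa-2 cells (Homo sapiens) for inhibition, read by MTT assay, with a stated time of 7 days; on this read-out higher numbers stand for weaker inhibition and lower numbers for stronger inhibition. Compound 1 `O=C([C@@H]1CCCN(S(=O)(=O)c2ccc(S(=O)(=O)C3COC3)cc2)C1)N1CCC(F)(F)CC1` gives 110 nM in this assay. Compound 2 `CCN(CC)S(=O)(=O)c1ccc(S(=O)(=O)N2CCC[C@@H](C(=O)N3CC[C@H](OC)C3)C2)cc1` gives 2460 nM in this assay, a much higher number than that of compound 1; compound 2 differs from compound 1 in more than one place, so the two values show only where each compound stands, not what any single change does. Of the two numbers, that of compound 1 is the lower one, and the gap to compound 2 lies beyond the usual scatter.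

Compound 3 `CC(C)NS(=O)(=O)c1ccc(S(=O)(=O)N2CCC[C@@H](C(=O)N3CCC(F)(F)CC3)C2)cc1` is not yet measured. It is made from compound 1 by one change on the sulfonyl sulfur: isopropylamino in place of oxetan-3-yl on a sulfonyl sulfur. For the measured compounds named here, no step between measured compounds shows what this change does on its own. Since compound 2, which also carries a sulfamoyl group there, gives 2460 nM in this assay, a move toward weaker inhibition is expected, though a smaller one than that gap. The expected step is a 3.0-fold higher number from compound 1 to compound 3 (0.48 log units; beyond the scatter). Compound 3 is therefore estimated at 330 nM, with a range from 100 nM to 1200 nM.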

Compound 3, half-maximal inhibitory concentration: 350 nM
Compound 3: the middle estimate sits 1.1-fold (0.03 log units) below what was measured; the measured number falls inside the stated range.
By their numbers in this assay, from the lowest: compound 1; then compound 3; then compound 2.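

For the compounds shown here, with the rest of compound 1 left in place, isopropylamino in place of oxetan-3-yl on a sulfonyl sulfur gives a 3.2-fold higher number from compound 1 to compound 3 (0.50 log units; beyond the scatter) in this assay, and this is the only direct reading of a single change at this position. The step is modest but beyond the scatter, so the position responds to this change, moving toward weaker inhibition even though the two groups have the same number of heavy atoms. The change removes the four-membered ring and its oxygen and brings in an open group with a nitrogen and a hydrogen-bond donor, all at once, and nothing measured here links the step to any one of these differences or explains it.

Isopropylsulfonyl, which keeps the open isopropyl group but has no nitrogen, would help separate the loss of the ring from the arrival of the nitrogen and its hydrogen. Cyclobutylsulfonyl, which keeps a four-membered ring without the oxygen, and N-methyl-N-isopropylsulfamoyl, which has no amide hydrogen, would each test a further part of the change, so it remains open which part accounts for the step.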